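One Added Methyl on an Aromatic Carbon

The compounds below may be only part of what the source reports. "The series", "measured", "known", "first", "only" and "open" are said of these compounds alone.

Compound 1 `CNC(=O)c1cc(C(=O)N[C@H]2[C@@H]3C[C@@H](OC)C[C@@H]32)n([C@@H](C)c2ccccc2)n1` reads 2.7 in a physicochemical assay for lipophilicity (on this read-out lower numbers stand for lower lipophilicity and higher numbers for higher lipophilicity), while compound 3 `CNC(=O)c1cc(C(=O)NC)n([C@@H](C)c2ccccc2)n1` reads 3 on the same scale. Compound 2 `CNC(=O)c1cc(C(=O)N[C@H]2CC[C@H](O)CC2)n([C@@H](C)c2ccccc2)n1` reads 2.9 here and stands within the scatter of both, with a number 0.20 log units higher from compound 1 to compound 2 (within the scatter) and a number 0.10 log units higher from compound 2 to compound 3 (within the scatter) as its two steps. Compound 4 `CNC(=O)c1cc(C(=O)N[C@H]2CC[C@H](O)CC2)n([C@@H](C)c2cccc(C)c2)n1` carries one change from compound 2, methyl in place of hydrogen on an aromatic carbon. Among the measured compounds shown here, no measured step touches that ring. All stayed within the scatter, even a number 0.30 log units higher from compound 1 to compound 3 (within the scatter) for a much larger exchange on an amide-type nitrogen. With one carbon added, a number 0.40 log units higher from compound 2 to compound 4 (beyond the scatter) is the expected modest rise in this assay for this change. Compound 4 is estimated at 3.3 with an expected range of 2.9 to 3.7 on this scale.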

Compound 4, distribution coefficient: 3.4
Compound 4: the middle estimate sits 0.10 log units below what was measured; the measured number falls inside the stated range.
By their numbers in this assay, from the lowest: compounds 1, 2 and 3 (each within the scatter of the next); then compound 4.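

On the ring of the 1-phenylethyl group, a single methyl gives a number 0.50 log units higher from compound 2 to compound 4 (beyond the scatter) in this assay. This is the first step among the compounds shown that lies beyond the scatter, so this ring position responds measurably to the addition of one carbon. Nothing available explains the size of this step.

Methyl is the only group shown at this place, and only this ring position is shown changed. As far as these compounds go, whether an amine, a carboxylic acid or a longer chain here would raise or lower the number remains open.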